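Swapping a small amine chain for a benzylpyrrolidine

The source may hold more compounds than are shown below. What is called first, only, known or untested is meant among the compounds shown, and "the series" means these compounds.

Measured so far:
compound 1 `CN(C)CC(=O)N1CCC(NS(=O)(=O)c2cc(S(=O)(=O)c3ccccc3)ccc2C(F)(F)F)CC1`: 100000 nM
compound 2 `CCNC(=O)N1CCC[C@H]1C(=O)N1CCC(NS(=O)(=O)c2cc(S(=O)(=O)c3ccccc3)ccc2C(F)(F)F)CC1`: 100000 nM

In a physicochemical assay for solubility (a higher number here means a more soluble compound, a lower number a less soluble compound), compound 1 gives 100000 nM. On these numbers compound 1 stands level with compound 2, which in this assay gives 100000 nM. For the measured compounds named here, the one step between the measured compounds is no change at the digits printed from compound 1 to compound 2 (within the scatter), so exchanging the (dimethylamino)methyl group for a 1-(ethylcarbamoyl)pyrrolidin-2-yl group left the solubility where it was.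

The unmeasured compound 3 `O=C([C@@H]1CCCN1Cc1ccccc1)N1CCC(NS(=O)(=O)c2cc(S(=O)(=O)c3ccccc3)ccc2C(F)(F)F)CC1` keeps the shared core of compound 1 and changes the same position: 1-benzylpyrrolidin-2-yl in place of (dimethylamino)methyl on a carbonyl carbon. Going by the values given here, only the step from compound 1 to compound 2 speaks to this change, and it showed nothing beyond the scatter. Among the compounds with values here, the group entering compound 3 is, however, larger than the one that entered compound 2 and carries an aromatic ring, so a modest fall is the more cautious expectation, with no change beyond the scatter also well possible. Compound 3 is therefore expected to show a step of a 2.5-fold lower number from compound 1 to compound 3 (0.40 log units; beyond the scatter) in this assay. For compound 3 the estimated value is 40000 nM, with a range from 8000 nM to 100000 nM.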

Compound 3, solubility: 25000 nM
For compound 3 the middle estimate is 1.6-fold (0.20 log units) above the measured one; low and high end bracket the measured number.
By their numbers in this assay, from the lowest: compound 3; then compounds 1 and 2 (each within the scatter of the next).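

In this assay, this position on the carbonyl carbon proves able to shift the read-out: placing 1-benzylpyrrolidin-2-yl there in place of (dimethylamino)methyl gives a 4.0-fold lower number from compound 1 to compound 3 (0.60 log units; beyond the scatter), whereas the earlier exchange had produced no change at the digits printed. The comparison with the closest neighbour narrows this further, since the pyrrolidine ring is common to both compounds and benzyl in place of ethylcarbamoyl on the amine nitrogen in a ring gives a 4.0-fold lower number from compound 2 to compound 3 (0.60 log units; beyond the scatter). So a step of the same size appears from either starting compound, and in the second comparison the change is confined to the group on that nitrogen, although no measurement here offers an explanation for the step.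

The compounds shown leave open whether the step belongs to the six-membered aromatic ring of the benzyl group or would also appear with a non-aromatic group on the same nitrogen, such as cyclohexylmethyl. A plain methyl group or an unsubstituted amine at that nitrogen would show how much of the step remains once the benzyl group is gone.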